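Changing the benzylamine tail of a potent serotonin receptor ligand

The source may report more compounds than this note shows. Statements on the series, on what has been measured and on what is new or still open speak of the compounds shown alone.

Measured so far:
compound 1, `O=S(=O)(NCC1CCN(CCCc2c[nH]c3ccc(-n4cnnc4)cc23)CC1)c1ccccc1`: 6.2 nM
compound 2, `CN(Cc1ccccc1)CC1CCN(CCCc2c[nH]c3ccc(-n4cnnc4)cc23)CC1`: 0.9 nM

Both compounds were tested in an assay on CHO cells for displacement of a labelled ligand from 5-hydroxytryptamine receptor 1D (Homo sapiens); a higher number here means a weaker inhibitor, a lower number a stronger inhibitor. Compound 2 gives the lower of the two numbers, with compound 1 at the higher number, a 6.9-fold lower number from compound 1 to compound 2 (0.84 log units; beyond the scatter). Among the measured compounds shown here, that single step, exchanging one attachment on the side chain for another, is the only measured change in this set. Compound 3, `CC(=O)Nc1ccc(CNCC2CCN(CCCc3c[nH]c4ccc(-n5cnnc5)cc34)CC2)cc1`, differs from compound 2 by (4-acetamidobenzyl)amino in place of benzyl(methyl)amino on a saturated chain carbon bound to a saturated ring carbon. For the measured compounds named here, no measured step describes this exact swap: compound 2 already carries an amine at this position, and compound 3 keeps an amine there too, so the change is smaller than the one from compound 1 to compound 2. Compound 3 is therefore expected to remain close to compound 2 in this assay, with an estimated step of a 1.7-fold higher number from compound 2 to compound 3 (0.22 log units; within the scatter), which lies within the usual scatter. The estimate for compound 3 is 1.5 nM, with a likely range from 0.4 nM to 6 nM.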

Compound 3, half-maximal inhibitory concentration: 4.2 nM
Compound 3: middle estimate off by 2.8-fold (0.45 log units), on the low side; low and high end bracket the measured number.
By their numbers in this assay, from the lowest: compound 2; then compounds 3 and 1 (each within the scatter of the next).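

In this assay, keeping an amine on this saturated chain carbon does not by itself preserve the low number of compound 2: the swap to (4-acetamidobenzyl)amino gives a 4.7-fold higher number from compound 2 to compound 3 (0.67 log units; beyond the scatter). The second step, a 1.5-fold lower number from compound 1 to compound 3 (0.17 log units; within the scatter), shows that 4-acetamidobenzyl and phenylsulfonyl on this amine nitrogen cannot be told apart here, so the advantage of compound 2 over compound 1 does not extend to every amine in this set. No measurement shown here bears on what lies behind these differences.

The swap from compound 2 to compound 3 joins two changes, the loss of the methyl and the gain of the acetamido group, and these compounds cannot separate them. As far as these compounds go, whether a plain benzylamino group would fall nearer compound 2 or compound 3 remains open.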